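Taking the Acetyl Group off Compound 1

The source may report more compounds than this note shows. Statements on the series, on what has been measured and on what is new or still open speak of the compounds shown alone.

In a functional assay on MCF7 cells (Homo sapiens) for cytotoxicity (on this read-out lower numbers stand for stronger inhibition and higher numbers for weaker inhibition), compound 1 `CC(=O)Nc1ccc(-c2nc3cccc(O)c3s2)cc1C` gives 48200 nM while compound 2 `Nc1ccc(-c2nc3cc(O)ccc3s2)cc1Cl` gives 60600 nM in the same test. Among the measured compounds shown here, these two numbers lie within the scatter of each other, so compound 1 stands level with the only other value available. Compound 3 `Cc1cc(-c2nc3cccc(O)c3s2)ccc1N` has not yet been measured. It differs from compound 1 by hydrogen in place of acetyl on a nitrogen on an aromatic ring which turns acetamido to amino. For the measured compounds named here, no step between measured compounds shows what such a change does in this assay so any expectation here is loose. Compound 2 at 60600 nM gives no hint of a large gain, so only a small move towards stronger inhibition, hardly beyond the scatter, is expected. The estimated change is a 1.6-fold lower number from compound 1 to compound 3 (0.21 log units; within the scatter) in this test. For compound 3 the estimated value is 30000 nM with an expected range from 8000 nM to 80000 nM in this test.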

Compound 3, half-maximal inhibitory concentration: 90800 nM
Beside the measured number, compound 3's estimate is 3.0-fold (0.48 log units) below it; measured number outside the range, above it.
By their numbers in this assay, from the lowest: compounds 1, 2 and 3 (each within the scatter of the next).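

In this assay, among the compounds shown here, the first direct reading of this change, hydrogen in place of acetyl on a nitrogen on an aromatic ring, gives a 1.9-fold higher number from compound 1 to compound 3 (0.28 log units; within the scatter), a step that stays within the scatter. The acetamido and amino forms are therefore not told apart by this read-out, even though the change removes three heavy atoms, including a double bond outside aromatic rings and a hydrogen-bond acceptor. No measurement shown here offers an explanation for this outcome.

From the compounds shown here alone, it remains open whether a longer acyl chain, such as butyryl, or a methanesulfonyl or benzoyl group on this nitrogen would give a step beyond the scatter. Going by these compounds, it is also open whether a dimethylamino group in place of amino would read any differently from compound 3 in this assay.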